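Swapping the Aromatic Arm of Compound 1

The source may hold more compounds than are shown below. What is called first, only, known or untested is meant among the compounds shown, and "the series" means these compounds.

Measured compounds:
compound 1 `O=c1cc(/C=N\c2ccccc2O)c2ccc(OCc3ccccc3)cc2o1` — 1290 nM
compound 2 `O=c1cc(/C=N\O)c2c(OCc3ccccc3)cc(OCc3ccccc3)cc2o1` — 38700 nM
compound 3 `O=c1cc(/C=N\c2ccccc2O)c2c(OCc3ccccc3)cc(OCc3ccccc3)cc2o1` — 7760 nM

In a functional assay, read by spectrophotometry, with a stated time of 3 min (on this read-out higher numbers stand for weaker inhibition and lower numbers for stronger inhibition), compound 1 gives the lowest of the three numbers. Its nearest neighbour is compound 3, reached by a 6.0-fold higher number from compound 1 to compound 3 (0.78 log units; beyond the scatter); compound 2 lies furthest away. Going by the values given here, the only step that changes the group on the carbon opposite the ring oxygen is a 5.0-fold lower number from compound 2 to compound 3 (0.70 log units; beyond the scatter), which shows that what sits there moves the read-out by a modest amount.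

Compound 4 `O=c1cc(-c2nc3ccccc3[nH]2)c2ccc(OCc3ccccc3)cc2o1` is the unmeasured compound. Among the compounds with values here, it differs from compound 1 in one place: a group of 9 heavy atoms (7 carbon, 2 nitrogen; one five-membered aromatic ring with 2 hetero atoms, one six-membered aromatic ring of carbon only) in place of a group of 9 heavy atoms (7 carbon, 1 nitrogen, 1 oxygen; one six-membered aromatic ring of carbon only), on an aromatic carbon No measured pair mirrors this swap; both groups carry one six-membered aromatic ring of carbon only and one hydrogen-bond donor, and the step from compound 2 to compound 3 is the only guide that the site tolerates a change of modest size in either direction. The account therefore expects no step beyond the scatter, with wide uncertainty, as a 1.2-fold higher number from compound 1 to compound 4 (0.07 log units; within the scatter). Compound 4 is estimated at 1500 nM, with a range from 300 nM to 8000 nM in this assay.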

Compound 4, half-maximal inhibitory concentration: "not active" (no number reported)
Compound 4 has no reported number here, and the estimate cannot be compared.
By their numbers in this assay, from the lowest: compound 1; then compound 3; then compound 2.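

In this assay, going by these compounds alone, compound 4 is reported as not active, without a number, so no step from compound 1 to compound 4 can be read. The compounds shown leave open how far the 1H-benzimidazol-2-yl group moves the read-out on the core of compound 1. No measurement shown here bears on this result.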